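A few compounds are considered here, and "the series" means these few. Any claim that something is new, unique, unknown or untested is made for them only; others in the source may bear on it.

Three compounds that share a chloro-substituted benzyl amide with a tetrazole-free description left aside have numbers in an ADME assay on Caco-2 cells (Homo sapiens) for permeability, read by LC-MS, in the apical to basolateral direction, with a stated time of 60 min, at pH 6.5; a higher number here means that the compound crosses the layer faster, a lower number that the compound crosses the layer more slowly. Compound 1 (`CCCC(=O)O[C@@H](C(=O)N1N=CC[C@H]1C(=O)NCc1cc(Cl)ccc1-n1cnnn1)c1ccc(F)cc1`) gives 25 10^-6 cm/s, and compound 3 (`O=C(NCc1cc(Cl)ccc1-n1cnnn1)[C@@H]1[C@H]2C[C@H]2CN1C(=O)[C@H](O)C1CCCCC1`) gives 25 10^-6 cm/s. Compound 2 (`O=C(NCc1cc(Cl)ccc1-n1cnnn1)[C@@H]1C[C@H]2C[C@H]2N1C(=O)[C@H](O)c1ccccc1`) gives 17 10^-6 cm/s, which lies within the scatter of both others, so the three numbers do not separate.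

Compound 4 (`CC(C)(C)[C@@H](O)C(=O)N1[C@@H]2C[C@@H]2C[C@H]1C(=O)NCc1cc(Cl)ccc1-n1cnnn1`) differs from compound 2 in one place: tert-butyl in place of phenyl on a saturated chain carbon bound to a carbonyl carbon and an oxygen on a saturated carbon. This is tert-butyl in place of phenyl on a saturated chain carbon bound to a carbonyl carbon and an oxygen on a saturated carbon.

For the measured compounds named here, no measured pair differs in one place only, so the data give no direct size for this change. Compound 1 at 25 10^-6 cm/s differs from compound 2 in more than one place and still stays within the scatter, and this supports expecting little movement in this assay. The estimated step of a 1.1-fold higher number from compound 2 to compound 4 (0.02 log units; within the scatter) is expected to stay within the scatter, with no firm direction. For compound 4 the expected value is 18 10^-6 cm/s, with an estimated range from 9 10^-6 cm/s to 35 10^-6 cm/s.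


Correction to the opening sentence, which should read in place of the first sentence above: "Three compounds have numbers in this assay."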

Compound 4, apparent permeability: 34 10^-6 cm/s
For compound 4 the middle estimate is 1.9-fold (0.28 log units) below the measured one, and the stated range covers the measured number.
By their numbers in this assay, from the lowest: compounds 2, 1, 3 and 4 (each within the scatter of the next).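

In this assay compound 2 and compound 4 form the first pair shown that differs in one place, and tert-butyl in place of phenyl on this saturated chain carbon gives a 2.0-fold higher number from compound 2 to compound 4 (0.30 log units; within the scatter) as the first direct size for this change. At this position, then, the six-membered aromatic ring can give way to a group with no ring while the difference stays within the scatter. Nothing shown offers a reason for this result.

The compounds shown leave open how an amine or a carboxylic acid at this place would read in this assay and whether a longer chain in place of tert-butyl would stay within the scatter of compound 4. They also leave open whether the same change gives a step of similar size on the core of compound 1 or of compound 3.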